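The compounds below may be only part of what the source reports. "The series", "measured", "known", "first", "only" and "open" are said of these compounds alone.

Measured compounds:
- compound 1 `CO[C@H]1O[C@H](COc2ccccc2C(C)C)[C@@H](O)[C@H](O)[C@H]1Oc1ccc(OC2CCCCC2)cc1`: 47000 nM
- compound 2 `CO[C@H]1O[C@H](COc2ccc(-c3ccccc3)cc2)[C@@H](O)[C@H](O)[C@H]1Oc1ccccc1`: 33000 nM
- compound 3 `CO[C@@H]1O[C@H](COc2ccc(-c3ccccc3)cc2)[C@@H](O)[C@H](O)[C@H]1Oc1ccccc1`: "not determined" (no result reported)

In a functional assay on HeLa cells (Homo sapiens) for cytotoxicity, read by MTT assay, with a stated time of 48 h (on this read-out higher numbers stand for an effect only at larger amounts of compound and lower numbers for an effect already at smaller amounts), compound 1 gives 47000 nM and compound 2 gives 33000 nM; the two values lie within the usual scatter of each other, so neither is set apart. Compound 3 stands without a number in this assay, its entry reading "not determined" (no result reported). What holds it to the series is the fact that compounds 2 and 3 differ only in the configuration as drawn, which gives no measured value to rest on; compound 3 can only be placed by way of compound 2, whose value is the nearest available.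

Compound 4 `CO[C@@H]1O[C@H](COc2ccc(-c3ccccc3)cc2)[C@@H](O)[C@H](O)[C@H]1Oc1cccc(C(C)C)c1` differs from compound 3 by isopropyl in place of hydrogen on an aromatic carbon. Within the data shown here, no measured pair spans this change, so the size of the step has to be judged without a measured precedent. Compound 1 carries an isopropyl group on its other phenoxy ring and ends within the scatter of compound 2, which gives no sign that an isopropyl on a phenoxy ring moves the read-out. The expectation in this assay is therefore for no step beyond the scatter, in either direction.

On that footing compound 4 is expected to give about 35000 nM, within a range from 12000 nM to 100000 nM.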

Compound 4, half-maximal effective concentration: 32000 nM
Compound 4: middle estimate off by 1.1-fold (0.04 log units), on the high side, and the stated range covers the measured number.
By their numbers in this assay, from the lowest: compounds 4, 2 and 1 (each within the scatter of the next).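

In this assay, among these compounds, compound 4 gives 32000 nM, but compound 3, the only compound differing from it in one place, stands without a number, so no new step can be read. Still open are the size of the change from hydrogen to isopropyl and whether configuration moves the read-out, a question resting on one pair: the fact that compounds 2 and 3 differ only in the configuration as drawn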